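A few compounds are considered here, and "the series" means these few. Any claim that something is new, unique, unknown or untested is made for them only; others in the source may bear on it.

Values in a functional assay on CAL-27 cells (Homo sapiens) for cytotoxicity, read by MTT assay, with a stated time of 72 h; on this read-out higher numbers stand for weaker inhibition and lower numbers for stronger inhibition:
- Compound 1 `CN(C)c1ccc(C(=O)N(CC(=O)NCc2ccccc2)Cc2ccc(C(=O)Nc3cc(-c4ccccc4)ccc3N)cc2)cc1`: 11100 nM
- Compound 2 `Cc1cc(C)cc(C(=O)N(CC(=O)NCc2ccccc2)Cc2ccc(C(=O)Nc3cc(F)ccc3N)cc2)c1`: 5720 nM
- Compound 3 `CN(C)c1ccc(C(=O)N(CC(=O)NCc2ccccc2)Cc2ccc(C(=O)Nc3ccccc3N)cc2)cc1`: 1600 nM

Compound 3 stands lowest of the three at 1600 nM. Compound 4 `Cc1cc(C)cc(C(=O)N(CC(=O)NCc2ccccc2)Cc2ccc(C(=O)Nc3ccccc3N)cc2)c1` has 3,5-dimethylphenyl in place of 4-(dimethylamino)phenyl on a carbonyl carbon. Going by the values given here, the only measured single-place step, a 6.9-fold lower number from compound 1 to compound 3 (0.84 log units; beyond the scatter), is modest but concerns a different change, so it bears on this one only indirectly. Among the compounds with values here, compound 2 also carries 3,5-dimethylphenyl and gives 5720 nM, yet no measured step isolates that group. A small upward step in this assay is therefore expected, close to the scatter: a 1.5-fold higher number from compound 3 to compound 4 (0.18 log units; within the scatter). For compound 4 the estimated value is 2400 nM, with an expected range from 1000 nM to 6000 nM.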

Compound 4, half-maximal inhibitory concentration: 1600 nM
Compound 4: middle estimate off by 1.5-fold (0.18 log units), on the high side; measured number inside the range.
By their numbers in this assay, from the lowest: compounds 3 and 4 (each within the scatter of the next); then compounds 2 and 1 (each within the scatter of the next).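

In this assay, 3,5-dimethylphenyl in place of 4-(dimethylamino)phenyl on the carbonyl carbon gives no change at the digits printed from compound 3 to compound 4 (within the scatter), so at this position the loss of the dimethylamino nitrogen leaves the number unmoved. Going by these compounds alone, the new compound also isolates the fluoro on an aromatic carbon for the first time, with hydrogen in its place giving a 3.6-fold lower number from compound 2 to compound 4 (0.55 log units; beyond the scatter). No evidence is available to account for either step. Still open, as far as these compounds go, is how a carboxylic acid or a morpholine would read on the carbonyl carbon, and whether chloro on the aromatic carbon would track fluoro.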